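Hydrazone swap on a shared core: toward compound 3

The source may hold more compounds than are shown below. What is called first, only, known or untested is meant among the compounds shown, and "the series" means these compounds.

Compound 1 `O=C(CSc1nnc(-c2ccncc2)o1)N/N=C/c1ccc([N+](=O)[O-])cc1`: 17900 nM
Compound 2 `Cc1ccc(/C=N/NC(=O)CSc2nnc(-c3ccncc3)o2)cc1`: 10000 nM

In a functional assay on HepG2 cells (Homo sapiens) for cytotoxicity, read by MTT assay, with a stated time of 48 h (a higher number here means a weaker inhibitor, a lower number a stronger inhibitor), compound 1 gives the highest of the two numbers, and its nearest neighbour, compound 2, differs only within the scatter. Compound 3 `O=C(CSc1nnc(-c2ccncc2)o1)N/N=C/c1ccco1` differs from compound 1 in one place: furan-2-yl in place of 4-nitrophenyl on a carbon with a double bond to nitrogen. Among the compounds with values here, the single measured step, a 1.8-fold lower number from compound 1 to compound 2 (0.25 log units; within the scatter), changed a group on that same aromatic ring and stayed within the scatter, but no step replaces the ring itself. Compound 3 is therefore expected to sit close to compound 1, with a 1.2-fold lower number from compound 1 to compound 3 (0.08 log units; within the scatter) not reaching beyond the scatter. The estimate for compound 3 in this assay is 15000 nM, ranging from 6000 nM to 40000 nM.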

Compound 3, half-maximal inhibitory concentration: 12500 nM
Compound 3: the middle estimate sits 1.2-fold (0.08 log units) above what was measured, and the stated range covers the measured number.
By their numbers in this assay, from the lowest: compounds 2, 3 and 1 (each within the scatter of the next).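

Exchanging the whole aromatic ring on the carbon with a double bond to nitrogen, rather than a group on that ring, gives no step beyond the scatter in this assay (a 1.4-fold lower number from compound 1 to compound 3 (0.16 log units; within the scatter); a 1.3-fold higher number from compound 2 to compound 3 (0.10 log units; within the scatter)). At this position, furan-2-yl therefore cannot be told apart from 4-nitrophenyl or 4-methylphenyl. Nothing available explains this result.

Still open, from the compounds shown here alone, is whether an amine or a carboxylic acid on the ring, or a longer chain in its place, would give a step beyond the scatter.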